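The compounds below may be only part of what the source reports. "The series", "measured", "known", "first", "only" and "open" are said of these compounds alone.

Measured so far: compound 1 `O=C(CCS(=O)(=O)c1cccc2ncsc12)N1CCN(c2ccnc(C(F)(F)F)c2)CC1` gives "not determined" (no result reported) in an ADME assay on microsomes from liver (Rattus norvegicus) for metabolic stability, read by LC-MS, with a stated time of 15 min, tested at 1 uM; on this read-out higher numbers stand for a more stable compound and lower numbers for a less stable compound; compound 2 `Cc1cc(F)cnc1N1CCN(C(=O)CCCc2cccc3ncsc23)[C@@H](C)C1` gives 5.3% in this assay.

Compound 1 stands nowhere on this read-out: no number was reported for it, so it provides no anchor. Compound 3 `O=C(CCS(=O)(=O)c1cccc2ncsc12)N1CCN(c2ccncc2F)CC1` carries the change (3-fluoropyridin-4-yl in place of 2-(trifluoromethyl)pyridin-4-yl on an amine nitrogen in a ring). For the measured compounds named here, no step between measured compounds exists to size this change, and compound 2 gives the only number in this assay, a low remaining fraction. In this assay no direction beyond the scatter can be assigned to the step from compound 1 to compound 3. For compound 3 the remaining fraction is estimated at 30%, within 5% to 75%.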

Compound 3, percent of the compound remaining: 29%
Compound 3: middle estimate off by 1 percentage points, on the high side, and the stated range covers the measured number.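

In this assay compound 3 gives 29% and compound 1 gives "not determined" (no result reported) so no new step can be read between them. The compounds shown leave open how replacing 2-(trifluoromethyl)pyridin-4-yl with 3-fluoropyridin-4-yl shifts the fraction remaining. No measured evidence bears on this result.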